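Amide chain variants on the shared furan-carboxamide core

The source may hold more compounds than are shown below. What is called first, only, known or untested is meant among the compounds shown, and "the series" means these compounds.

Compound 1 `Cc1cc2c(cc1Cc1ccc(C(=O)NC[C@H]3CC[C@H](C(N)=O)CC3)o1)C(C)(C)CCC2(C)C` is the reference point of this small set. In an assay on isolated protein for binding affinity to Gonadotropin-releasing hormone receptor (Rattus norvegicus) (a lower number here means a stronger inhibitor, a higher number a weaker inhibitor), compound 1 gives 270 nM, the lowest number among the two measured. Among the compounds with values here, the only other measured member, compound 2 `Cc1cc2c(cc1Cc1ccc(C(=O)NCC3CCC(CNC(=O)C(F)(F)F)CC3)o1)C(C)(C)CCC2(C)C`, carries a trifluoroacetamidomethyl group on the cyclohexane in place of the carboxamide; in this assay compound 2 gives 2720 nM, a higher number than compound 1 and beyond the scatter, so compound 1 stands alone at the stronger end.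

Compound 3 `Cc1cc2c(cc1Cc1ccc(C(=O)NCC3CCN(C(=N)N)CC3)o1)C(C)(C)CCC2(C)C` has not been measured. Its difference from compound 1 is a group of 9 heavy atoms (6 carbon, 3 nitrogen; one six-membered non-aromatic ring with 1 hetero atom) in place of a group of 9 heavy atoms (7 carbon, 1 nitrogen, 1 oxygen; one six-membered non-aromatic ring of carbon only), on a saturated chain carbon bound to an amide-type nitrogen, in words a group of 9 heavy atoms (6 carbon, 3 nitrogen; one six-membered non-aromatic ring with 1 hetero atom) in place of a group of 9 heavy atoms (7 carbon, 1 nitrogen, 1 oxygen; one six-membered non-aromatic ring of carbon only), on a saturated chain carbon bound to an amide-type nitrogen.

Within the data shown here, no measured pair shows such a change, so the expectation rests on compound 1 alone. For compound 3 the step of a 1.1-fold lower number from compound 1 to compound 3 (0.03 log units; within the scatter) is estimated to be small, not beyond the scatter in either direction. Compound 3 is therefore expected to give about 250 nM in this assay, with a range from 50 nM to 1300 nM.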

Compound 3, inhibition constant: 2040 nM
Compound 3: middle estimate off by 8.2-fold (0.91 log units), on the low side; measured number outside the range, above it.
By their numbers in this assay, from the lowest: compound 1; then compounds 3 and 2 (each within the scatter of the next).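

Within the data shown here, exchanging 4-carbamoylcyclohexyl for the entering group, on a saturated chain carbon bound to an amide-type nitrogen, gives a 7.6-fold higher number from compound 1 to compound 3 (0.88 log units; beyond the scatter) in this assay, the first step in this set that can be read at one place. Both groups hold 9 heavy atoms and one six-membered non-aromatic ring, so at this position a matching heavy-atom count and ring size do not by themselves keep the number of compound 1. The exchange alters several things at once, replacing a ring of carbon only with a ring with 1 hetero atom, changing the atom make-up, and removing the 2 defined stereocentres, and nothing available explains the step or ties it to any one of these changes.

Among these compounds, it remains open whether the ring hetero atom or the end group on the ring accounts for the step, and the single step gives no separate reading of either. An amine or a carboxylic acid in place of the carboxamide on the cyclohexane would test how much of the number of compound 1 depends on that carboxamide.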